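Lengthening the side chain by one more carbon

The compounds below may be only part of what the source reports. "The series", "measured", "known", "first", "only" and "open" are said of these compounds alone.

Measured so far:
compound 1 `CCCc1ccc(NC(=O)N[C@H](C)c2ccccc2)cc1`: 35%
compound 2 `CCCCCc1ccc(NC(=O)N[C@H](C)c2ccccc2)cc1`: 97%

In an ADME assay on the whole organism with Oryza sativa as the target, tested at 10 uM (on this read-out lower numbers stand for a stronger effect and higher numbers for a weaker effect at the one concentration tested), compound 2 gives the higher of the two numbers shown, while compound 1 gives 35%. Among the compounds with values here, the only step measured, a number 62 percentage points higher from compound 1 to compound 2 (beyond the scatter), is a large one and lies beyond the scatter. Compound 3 `CCCCCCc1ccc(NC(=O)N[C@H](C)c2ccccc2)cc1` is not yet measured; it differs from compound 2 by methyl in place of hydrogen on a saturated chain carbon, five bonds along the chain from an aromatic carbon. This continues the same direction of change as the measured step, but compound 2 already stands close to the top of the scale in this assay, so there is little room for a further rise of that kind. The expected step is therefore a number 3 percentage points higher from compound 2 to compound 3 (within the scatter), which means no change beyond the scatter. For compound 3 the estimate in this assay is 100%, with a range from 85% to 115%.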

Compound 3, a percentage reported as activity, at one concentration (the size of the read-out at that concentration, not a potency): 101%
The estimate for compound 3 lay 1 percentage points below the measured number; the range from low to high includes it.
By their numbers in this assay, from the lowest: compound 1; then compounds 2 and 3 (each within the scatter of the next).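

In this assay, methyl in place of hydrogen on a saturated chain carbon, five bonds along the chain from an aromatic carbon, gives a number 4 percentage points higher from compound 2 to compound 3 (within the scatter) and so, unlike the earlier ethyl step, this change does not register beyond the scatter. Taken as a whole, the change from the shorter chain gives a number 66 percentage points higher from compound 1 to compound 3 (beyond the scatter) and so compound 1 stands apart, while compound 2 and compound 3 cannot be told apart. Nothing available accounts for this levelling off.

A butyl chain, sitting in length between the chains of compound 1 and compound 2, could show whether the number climbs gradually or jumps abruptly. An octyl chain, longer than any shown here, could test whether the number stays at this level.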